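Replacing 4-bromophenyl in compound 3 with 3-methoxyphenyl

A few compounds are considered here, and "the series" means these few. Any claim that something is new, unique, unknown or untested is made for them only; others in the source may bear on it.

Compound 1 `Cn1cc(C2CC(c3ccccc3)=NN2C(=O)c2ccncc2)c2ccccc21`: 590 nM
Compound 2 `COc1ccc(C2=NN(C(=O)c3ccncc3)C(c3cn(C)c4ccc(Br)cc34)C2)cc1OC`: > 10000 nM (a limit)
Compound 3 `COc1ccc2c(c1)c(C1CC(c3ccc(Br)cc3)=NN1C(=O)c1ccc(OC)nc1)cn2C`: > 10000 nM (a limit)

All three compounds were tested in a functional assay on HeLa cells (Homo sapiens) for inhibition, read by MTT assay, with a stated time of 48 h; on this read-out higher numbers stand for weaker inhibition of growth and lower numbers for stronger inhibition of growth. Compound 1 gives a true number there, 590 nM. Compound 2 reaches only a limit, > 10000 nM. Compound 3 likewise reaches only a limit, > 10000 nM. Its place on the numbers shown is the limit of > 10000 nM in this assay, at which 2 of the 3 values shown sit.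

The next compound, compound 4 `COc1cccc(C2=NN(C(=O)c3ccc(OC)nc3)C(c3cn(C)c4ccc(OC)cc34)C2)c1`, has not yet been measured. It changes one group of compound 3: 3-methoxyphenyl in place of 4-bromophenyl on a carbon with a double bond to nitrogen. The (6-methoxypyridin-3-yl)carbonyl group stays in place. Among the measured compounds shown here, no step between measured compounds gives the size of such a swap, so the expectation rests on the values alone. Compound 1, with 590 nM, shows that a number can be read in this assay, but it differs from compound 3 in more than this one group. Only a modest move toward stronger inhibition of growth is expected: the estimated change is an at least 1.4-fold lower number from compound 3 to compound 4 (0.15 log units; that floor lies within the scatter). A report of only a limit is about as likely as a number. For compound 4 the expected value is 7000 nM, with an estimated range from 1500 nM to 30000 nM.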

Compound 4, concentration for 50% growth inhibition: 340 nM
Estimate against measurement, compound 4: 21-fold (1.31 log units) above; the measured number lies below the stated range.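

The carbon with a double bond to nitrogen, two ring bonds from the ring atom that bears a (6-methoxypyridin-3-yl)carbonyl group, proves to be a position where one change can decide the read-out in this assay: 3-methoxyphenyl in place of 4-bromophenyl gives an at least 29-fold lower number from compound 3 to compound 4 (1.46 log units; beyond the scatter). Compound 3 stands only at a limit, so this step gives a floor and not a full size: the limit of > 10000 nM in this assay, at which 2 of the 4 values shown sit. The (6-methoxypyridin-3-yl)carbonyl group stays in place across the step, and compound 4 still gives 340 nM, so that group does not by itself keep a compound from giving a true number.

This single swap removes the bromine and adds the methoxy group in one move, and it also shifts the substituent on the phenyl ring, so the pair cannot separate these changes from one another. The compounds shown also leave open how 4-methoxyphenyl, 3-bromophenyl, or a phenyl ring carrying an amine at this position would read in this assay.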